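The source may hold more compounds than are shown below. What is called first, only, known or untested is meant among the compounds shown, and "the series" means these compounds.

Measured so far in a functional assay on the whole organism (Ear) for inhibition, with Mus musculus as the target, at a dose of 40 mg/kg by the oral route; a lower number here means less inhibition, a higher number more inhibition at the dose given (going by the name of the read-out):
compound 1, `CC(=O)Oc1ccc(-c2ccc(F)cc2F)cc1C(=O)Nc1ccccc1`: 23.2%
compound 2, `CC(=O)Oc1ccc(-c2ccc(F)cc2F)cc1C(=O)Nc1cccc(C)c1`: 12.8%

Among the compounds with values here, compound 1 stands highest of the two numbers in this assay; its nearest neighbour is compound 2, and the single measured step, a number 10.4 percentage points lower from compound 1 to compound 2 (beyond the scatter), is beyond the scatter and modest. That step concerns a methyl in place of hydrogen on an aromatic carbon and leaves the ester untouched.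

Compound 3, `O=C(Oc1ccc(-c2ccc(F)cc2F)cc1C(=O)Nc1ccccc1)c1ccccc1`, is not yet measured. It differs from compound 1 at another place altogether: phenyl in place of methyl on a carbonyl carbon. Acetyl becomes benzoyl, acetoxy becomes benzoyloxy. Within the data shown here, no measured step touches the carbonyl carbon or the ester, so the step from compound 1 to compound 2 gives no guide to size or direction here; it shows only that a single-group change can move the read-out in this assay beyond the scatter. With nothing bearing directly on the change, no step beyond the scatter is expected, a number 3.2 percentage points lower from compound 1 to compound 3 (within the scatter), and the range is set wide to cover the uncertainty. Compound 3 is therefore estimated at 20%, between 3% and 42%.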

Compound 3, a percentage reported as inhibition, in the whole organism at one dose (the size of the read-out at that dose, not a potency): 19.8%
Compound 3: middle estimate off by 0.2 percentage points, on the high side; the range from low to high includes it.
By their numbers in this assay, from the lowest: compounds 2, 3 and 1 (each within the scatter of the next, the first and the last beyond it).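

On the carbonyl carbon of the ester, phenyl in place of methyl (acetyl to benzoyl) gives no separation in this assay: the change is a number 3.4 percentage points lower from compound 1 to compound 3 (within the scatter), although the entering group has six heavy atoms and a ring where the leaving group has one heavy atom and none. Within the data shown here, the earlier step, a number 10.4 percentage points lower from compound 1 to compound 2 (beyond the scatter), concerned an aromatic carbon and lay beyond the scatter, so this is the first reading at the carbonyl carbon, and here a much larger group does not move the read-out beyond the scatter. Nothing measured bears on why the two acyl groups read alike.

Open at this position are other acyl groups, such as a longer chain or an amine on the carbonyl carbon in place of the methyl, and a free hydroxyl in place of acetoxy, which would test whether the ester is needed for the read-out at all. Also open, as far as these compounds go, is whether methyl in place of hydrogen on the aromatic carbon, as in compound 2, has the same effect when the ester is benzoyloxy rather than acetoxy.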